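Bulkier aromatic groups on the sulfonyl sulfur

The source may report more compounds than this note shows. Statements on the series, on what has been measured and on what is new or still open speak of the compounds shown alone.

Compound 1 `CN1CCC(N(C)C(=O)C2CN(S(=O)(=O)c3cccc4c(Cl)cccc34)c3ccccc32)CC1` gives 5.01 nM in a functional assay on CHO cells for antagonist activity at 5-hydroxytryptamine receptor 6 (Homo sapiens), read by FLIPR; on this read-out higher numbers stand for weaker inhibition and lower numbers for stronger inhibition; compound 2 `CN1CCC(N(C)C(=O)C2CN(S(=O)(=O)C3=CC4CCOC4C=C3)c3ccccc32)CC1` gives 31.6 nM; compound 3 `CN1CCC(N(C)C(=O)C2CN(S(=O)(=O)c3ccccc3)c3ccccc32)CC1` gives 316 nM.

Compound 3 stands highest of the three, that is, it is the weakest inhibitor: a 10-fold higher number from compound 2 to compound 3 (1.00 log units; beyond the scatter) and a 63-fold higher number from compound 1 to compound 3 (1.80 log units; beyond the scatter), both beyond the scatter. Compound 4 `COc1cc(C)c(S(=O)(=O)N2CC(C(=O)N(C)C3CCN(C)CC3)c3ccccc32)c(C)c1C` carries the change (4-methoxy-2,3,6-trimethylphenyl in place of phenyl on a sulfonyl sulfur). Going by these compounds, the two measured steps show that a plain phenyl on the sulfonyl sulfur gives markedly higher numbers than a larger group in the same place, so replacing phenyl by a larger, substituted phenyl is expected to lower the number, though how far a methoxy-trimethylphenyl behaves like the bicyclic groups is unknown. The step of an 11-fold lower number from compound 3 to compound 4 (1.02 log units; beyond the scatter) is therefore expected, giving compound 4 an estimated 30 nM, with a range of 8 nM to 120 nM.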

Compound 4, inhibition constant: 100 nM
For compound 4 the middle estimate is 3.3-fold (0.52 log units) below the measured one, within the range that was stated.
By their numbers in this assay, from the lowest: compound 1; then compound 2; then compound 4; then compound 3.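

Putting methoxy and methyl groups on the phenyl at the sulfonyl sulfur lowers the number (a 3.2-fold lower number from compound 3 to compound 4 (0.50 log units; beyond the scatter)), so a substituted single ring can improve on plain phenyl. That gain is only part of what the other groups achieve (a 3.2-fold higher number from compound 2 to compound 4 (0.50 log units; beyond the scatter); a 20-fold higher number from compound 1 to compound 4 (1.30 log units; beyond the scatter)). Heavy-atom count alone does not set the order, since the group in compound 4 has more heavy atoms than that in compound 2 yet gives the higher number.

Which of the methoxy and methyl groups carries the step stays open, as does the effect of an amine or a carboxylic acid on that ring. Nothing given here explains this ranking.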